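Ester to Alcohol on a Chlorinated Tetrahydropyran Core

This account rests on a few compounds, and the source may have more. Where it says the series, first, only, none or still open, it means among the compounds named here.

Measured so far in a functional assay on the whole organism (Abdomen, strain Swiss albino) for inhibition, with Mus musculus as the target, in the writhing test, with a stated time of 30 min, at a dose of 30 mg/kg by the oral route; on this read-out higher numbers stand for more inhibition at the one dose given (going by the name of the read-out) and lower numbers for less inhibition:
compound 1 `OC[C@H]1CCC[C@@H](c2ccc3ccccc3c2)O1` — 55.7%
compound 2 `OC[C@H]1CCC[C@@H](c2cccc3ccccc23)O1` — 39.2%
compound 3 `CC(C)C(=O)OC[C@H]1C[C@@H](Cl)C[C@@H](c2ccc3ccccc3c2)O1` — 44.4%

Compound 3 stands second highest of the three numbers. Its nearest neighbour is compound 2, whose value lies lower by an amount within the scatter, so the two cannot be told apart. Compound 1 lies furthest off, higher by an amount beyond the scatter.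

Compound 4 `OC[C@H]1C[C@@H](Cl)C[C@@H](c2ccc3ccccc3c2)O1` differs from compound 3 in one place: hydrogen in place of isopropylcarbonyl on an oxygen on a saturated carbon. Among the compounds with values here, no measured pair shows this change on its own. Compound 1 also carries the hydroxymethyl group and, lacking the chlorine, gives 55.7%, which sits above compound 3; that second difference keeps the comparison loose. The step from compound 3 to compound 4 is expected to be small and upward, likely within the scatter: the expected step is a number 5.6 percentage points higher from compound 3 to compound 4 (within the scatter). Compound 4 is therefore estimated at 50%, within a range from 36% to 64%.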

Compound 4, a percentage reported as inhibition, in the whole organism at one dose (the size of the read-out at that dose, not a potency): 46.6%
The estimate for compound 4 lay 3.4 percentage points above the measured number, within the range that was stated.
By their numbers in this assay, from the lowest: compounds 2, 3, 4 and 1 (each within the scatter of the next, the first and the last beyond it).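

In this assay, the first pair differing only at this oxygen gives a number 2.2 percentage points higher from compound 3 to compound 4 (within the scatter), so on the chlorinated core the isopropylcarbonyl ester and the free alcohol cannot be told apart at the one dose given. Within the data shown here, the change of chloro in place of hydrogen on a saturated ring carbon, also seen here for the first time on its own, gives a number 9.1 percentage points lower from compound 1 to compound 4 (within the scatter), so neither single change separates its two compounds on this read-out. Nothing measured here bears on either step.

The compounds shown leave open whether an acetyl or a benzoyl group on that oxygen, or an amine in place of the hydroxy group, would stay within the same band. Going by these compounds, whether fluoro or methoxy on that ring carbon would match chloro also remains open.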